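Ester swap from cyclobutyl to cyclopropylmethyl: expected inhibition

A few compounds are considered here, and "the series" means these few. Any claim that something is new, unique, unknown or untested is made for them only; others in the source may bear on it.

Compound 1 `CC1=C(C(=O)OCc2ccccc2)C(c2cccs2)NC(=O)N1` gives 8% in an assay on membranes from HeLa cells for displacement of a labelled ligand from adenosine receptor A3 (Homo sapiens), read by scintillation counting, with a stated time of 180 min, tested at 1 uM; on this read-out lower numbers stand for less inhibition and higher numbers for more inhibition at the one concentration tested (going by the name of the read-out). For the measured compounds named here, compound 2 `CC1=C(C(=O)OC2CCC2)C(c2cccs2)NC(=O)N1` gives 2% in this assay, the lowest of the two numbers, and the only step measured so far, a number 6 percentage points lower from compound 1 to compound 2 (within the scatter), lay within the scatter. Compound 3 `CC1=C(C(=O)OCC2CC2)C(c2cccs2)NC(=O)N1` differs from compound 2 by cyclopropylmethyl in place of cyclobutyl on an oxygen next to a carbonyl group. Going by the values given here, the one step available, a change of the group on the same oxygen, did not move the read-out beyond the scatter, so no step beyond the scatter is expected in this assay here either. Compound 3 is therefore expected to give 5%, between -5% and 15%. That amounts to an expected step of a number 3 percentage points higher from compound 2 to compound 3 (within the scatter), within the scatter.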

Compound 3, a percentage reported as inhibition, at one concentration (the size of the read-out at that concentration, not a potency): 1%
Compound 3: the middle estimate sits 4 percentage points above what was measured; low and high end bracket the measured number.
By their numbers in this assay, from the lowest: compounds 3, 2 and 1 (each within the scatter of the next).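

In this assay the step of a number 1 percentage points lower from compound 2 to compound 3 (within the scatter) comes with cyclopropylmethyl in place of cyclobutyl on the oxygen, so this rearrangement of the same count of carbons stays within the scatter. The step of a number 7 percentage points lower from compound 1 to compound 3 (within the scatter) also stays within the scatter, with cyclopropyl in place of phenyl on the saturated chain carbon, so all three esters read alike at this position. Nothing measured here offers an explanation. On these data alone, whether an amine or a carboxylic acid on this ester group would move the read-out remains open, as does the effect of a longer chain.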